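A few compounds are considered here, and "the series" means these few. Any claim that something is new, unique, unknown or untested is made for them only; others in the source may bear on it.

Measured compounds:
- compound 1 `BrC12CCCC3CC(CCC31)C2`: no result reported in an ADME assay (Gallus gallus) for cytotoxicity, read by microscopy, with a stated time of 24 h; on this read-out lower numbers stand for higher toxicity in this test and higher numbers for lower toxicity in this test
- compound 2 `O=C(O)C12CCCC3CC(CCC31)C2`: 10000000 nM
- compound 3 `O=C(Cl)C12CCCC3CC(CCC31)C2`: no result reported in this assay

Compound 1 stands nowhere on the numbers: in this assay it has no single number, and compound 3 likewise has none. For the measured compounds named here, the only value in the set belongs to compound 2, which in this assay gives 10000000 nM. Going by the values given here, no step between two measured compounds can be drawn from these data.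

Compound 4 `NC(=O)C12CCCC3CC(CCC31)C2` is the compound still to be measured. It differs from compound 1 by carbamoyl in place of bromo on a saturated ring carbon. Since compound 1 carries no number, no direction or size of step in this assay can be stated for this change; any movement beyond the usual scatter is an open question, and none is assumed here. The carbamoyl group of compound 4 sits on the same saturated ring carbon of the shared core that carries the carboxylic acid in compound 2 and the carbonyl chloride in compound 3.

The minimum cytotoxic concentration of compound 4 is estimated at 5000000 nM, within a range of 1000000 nM to 10000000 nM, because compound 2 gives 10000000 nM in this assay.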

Compound 4, minimum cytotoxic concentration: 5200000 nM
Compound 4: the middle estimate sits 1.0-fold (0.02 log units) below what was measured; the measured number falls inside the stated range.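

In this assay, for the compounds shown here, this result gives the first comparison at this saturated ring carbon of the shared core: amino in place of hydroxy on a carbonyl carbon comes out as a 1.9-fold lower number from compound 2 to compound 4 (0.28 log units; within the scatter) in the minimum cytotoxic concentration. On these two compounds, then, the read-out does not separate the carboxylic acid from the carbamoyl group, and both sit in the same narrow band at this position. Nothing in the data speaks to what lies behind this result.

The step from compound 1 to compound 4 cannot be read, and neither can any step involving compound 3, so the bromo and carbonyl chloride groups stay unplaced against the others. As far as these compounds go, whether an amine, a methyl ester or a longer chain on this ring carbon would stay in that band remains open.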